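Halogen swap on the sugar of a fluorocytosine nucleoside series

A few compounds are considered here, and "the series" means these few. Any claim that something is new, unique, unknown or untested is made for them only; others in the source may bear on it.

Measured so far:
- compound 1, `Nc1nc(=O)n(C2OC(CO)C(I)C2O)cc1F`: 10 ug/mL
- compound 2, `Cc1ccc(S(=O)(=O)O[C@@H]2[C@@H](O)[C@H](n3cc(F)c(N)nc3=O)O[C@@H]2CO)cc1`: 8 ug/mL

Both compounds were tested in a functional assay on L5178Y cells (Mus musculus) for antiproliferative activity; a lower number here means a stronger inhibitor, a higher number a weaker inhibitor. Compound 1 gives 10 ug/mL and holds the highest number of the two; compound 2 gives 8 ug/mL, and the gap between compound 2 and compound 1 lies within the scatter, so the two values are read as equivalent. Among the measured compounds shown here, no step between measured compounds is available for this series.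

The next compound, compound 3, `Nc1nc(=O)n(C2OC(CO)C(Br)C2O)cc1F`, differs from compound 1 by a single change: bromo in place of iodo on a saturated ring carbon. Only the halogen on a saturated ring carbon of the five-membered ring changes, with no change in donors, acceptors or charge.

For the measured compounds named here, with no measured step to lean on, the expectation is that the change from compound 1 to compound 3 produces a 1.2-fold higher number from compound 1 to compound 3 (0.08 log units; within the scatter), a shift not beyond the scatter. Compound 3 is therefore estimated at 12 ug/mL in this assay, within a range of 4 ug/mL to 40 ug/mL.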

Compound 3, concentration for 50% inhibition: 2.6 ug/mL
Compound 3: the middle estimate sits 4.6-fold (0.66 log units) above what was measured, outside the stated range (below it).
By their numbers in this assay, from the lowest: compound 3; then compounds 2 and 1 (each within the scatter of the next).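

In this assay, the halogen on this saturated ring carbon is not a silent exchange: bromo in place of iodo gives a 3.8-fold lower number from compound 1 to compound 3 (0.59 log units; beyond the scatter), a step beyond the scatter, so this position responds to the identity of the halogen even with no change in donors, acceptors or charge. As a single step between two halogens, it gives a direction for this pair only and no trend across the halogens. Nothing measured on these compounds accounts for the step.

From the compounds shown here alone, whether chloro or fluoro on the same ring carbon would extend the change from iodo to bromo remains open. Also open, going by these compounds, is whether a halogen is needed there at all, a question that an amine or an azido group in its place would address.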